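The compounds below may be only part of what the source reports. "The series", "measured", "known", "first", "only" and "open" are said of these compounds alone.

In a functional assay on B16 cells (Mus musculus) for inhibition (a lower number here means a stronger inhibitor, a higher number a weaker inhibitor), compound 1 `CC(=O)Oc1ccc(/C=C/C(=O)OC2CCCCC2)cc1OC(C)=O` gives 200 nM and compound 2 `O=C(/C=C/c1ccc(O)c(O)c1)NC1CCCC1` gives 30000 nM as the higher of the two numbers, which makes compound 2 the weaker inhibitor by a gap beyond the usual scatter. For the measured compounds named here, compound 3 `O=C(/C=C/c1ccc(O)c(O)c1)NC1CCCCC1` keeps the rest of compound 2 and carries cyclohexyl in place of cyclopentyl on an amide-type nitrogen as its only change. Going by the values given here, no two measured compounds differ in just one place, so the data offer no direct guide to this swap. Starting from compound 2 at 30000 nM and seeing one carbon-only ring replace another, the expected shift in this assay is none beyond the scatter, with a slight lean towards a lower number. The estimated move a 1.5-fold lower number from compound 2 to compound 3 (0.18 log units; within the scatter) is therefore small. For compound 3 the expected value is 20000 nM with a range of 7000 nM to 60000 nM in this estimate.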

Compound 3, half-maximal inhibitory concentration: 2800 nM
Compound 3: the middle estimate sits 7.1-fold (0.85 log units) above what was measured; the whole stated range lies above it.
By their numbers in this assay, from the lowest: compound 1; then compound 3; then compound 2.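

In this assay, the group on the amide-type nitrogen matters much more than the small size of this change might suggest: cyclohexyl in place of cyclopentyl gives an 11-fold lower number from compound 2 to compound 3 (1.03 log units; beyond the scatter). Both groups are carbon-only rings with no hydrogen-bond donors or acceptors and no net charge, so a change in ring size alone is enough to shift the number well beyond the scatter at this position. Nothing measured here explains why the six-membered ring gives the stronger inhibitor.

As far as these compounds go, a single step cannot establish a trend with ring size, so it remains open whether a cycloheptyl ring would lower the number further or raise it again. It is also unclear how an open-chain group such as hexyl, or a cyclohexyl ring carrying an amine, would compare at this nitrogen.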